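Acyloxymethyl phosphonate prodrugs: hepatocyte half-life notes

This account rests on a few compounds, and the source may have more. Where it says the series, first, only, none or still open, it means among the compounds named here.

In an ADME assay on cells (Hepatocyte, Homo sapiens) for pharmacokinetics (on this read-out higher numbers stand for a longer-lived compound and lower numbers for a shorter-lived compound), compound 1 `CCc1cc(C(=O)OCO[P@@]2(=O)OCC(C)(C)[C@H](C(=O)NCCC(=O)OC)O2)n(C)n1` gives 0.3 h.
In this assay compound 2 `COC(=O)CCNC(=O)[C@@H]1O[P@@](=O)(OCOC(=O)c2scnc2C)OCC1(C)C` gives 0.5 h.

Within the data shown here, compound 2 stands beside compound 1 on these numbers: the only measured step, a 1.7-fold higher number from compound 1 to compound 2 (0.22 log units; within the scatter), lies within the scatter, so the two values cannot be told apart. That step exchanged the aromatic group on the carbonyl carbon of the acyloxymethyl ester.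

Compound 3 `COC(=O)CCNC(=O)[C@@H]1O[P@@](=O)(OCOC(=O)c2cc(C(C)(C)C)n[nH]2)OCC1(C)C` is the next member in the same place: 3-(tert-butyl)-1H-pyrazol-5-yl in place of 4-methyl-1,3-thiazol-5-yl on a carbonyl carbon. Among the measured compounds shown here, the one step that bears on it, a 1.7-fold higher number from compound 1 to compound 2 (0.22 log units; within the scatter), changed the same position and stayed within the scatter, so in this assay no step beyond the scatter is expected for compound 3, and no change at the digits printed from compound 2 to compound 3 (within the scatter) is the estimated change from compound 2. Compound 3 is therefore expected to give 0.5 h, with a range from 0.2 h to 1.2 h, in this assay.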

Compound 3, half-life: 0.5 h
Compound 3: middle estimate and measured number agree at the digits printed; the measured number falls inside the stated range.
By their numbers in this assay, from the lowest: compounds 1, 2 and 3 (each within the scatter of the next).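

On a carbonyl carbon, 3-(tert-butyl)-1H-pyrazol-5-yl in place of 4-methyl-1,3-thiazol-5-yl brings 9 heavy atoms for 6 and 1 hydrogen-bond donor for 0, yet this assay shows no change at the digits printed from compound 2 to compound 3 (within the scatter). The exchange between the two pyrazolyl groups reads the same way, with a 1.7-fold higher number from compound 1 to compound 3 (0.22 log units; within the scatter), so the three aromatic groups shown at this place cannot be told apart on half-life. No evidence on why these changes leave the half-life within the scatter is at hand.

Open, as far as these compounds go, is whether any group on this carbonyl carbon gives a step beyond the scatter. A phenyl ring carrying an amine or a carboxylic acid, or an open alkyl chain in place of the five-membered aromatic ring, would test this.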